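The source may hold more compounds than are shown below. What is called first, only, known or untested is meant among the compounds shown, and "the series" means these compounds.

Measured compounds:
compound 1 `N#CC1=C(N)OC(c2c[nH]c3ccccc23)=C(C#N)C1c1cccc2ccccc12`: 4.7%
compound 2 `N#CC1=C(N)OC(c2c[nH]c3ccccc23)=C(C#N)C1c1ccc2ccccc2c1`: "not active" (no number reported)

In a functional assay, tested at 50 ug/mL (a higher number here means a stronger effect of the compound at the concentration tested, a lower number a weaker effect), compound 1 gives 4.7%. In this assay compound 2 is reported only as "not active" (no number reported), so no number places it on the scale; it stands below any measurable effect. Compound 3 `N#CC1=C(N)OC(c2c[nH]c3ccccc23)=C(C#N)C1c1ccccc1F` differs from compound 2 by one exchange: 2-fluorophenyl in place of naphthalen-2-yl on a saturated ring carbon. With both measured compounds near the floor, no step beyond the usual scatter is expected here, in either direction. Compound 3 is therefore estimated at 3%, within 0% to 12%, with a fair chance that only an inactive call is reported.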

Compound 3, a percentage reported as activity, at one concentration (the size of the read-out at that concentration, not a potency): "not active" (no number reported)
Compound 3: no number reported, so the estimate cannot be set against anything.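

Compound 2 and compound 3 are both reported in this assay only as not active, so no step can be read between them. No evidence bears on this result. The compounds shown leave open whether any group on the saturated ring carbon gives an effect beyond the usual scatter.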